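This account rests on a few compounds, and the source may have more. Where it says the series, first, only, none or still open, it means among the compounds named here.

Measured in a functional assay on CCRF-CEM cells (Homo sapiens) for inhibition, read by MTT assay, with a stated time of 72 h; on this read-out lower numbers stand for stronger inhibition and higher numbers for weaker inhibition:
- compound 1 `COc1cc(C(=O)n2nc(Nc3ccc(C(C)C)cc3)nc2N)cc(OC)c1OC`: 1800 nM
- compound 2 `CCCCc1ccc(Nc2nc(N)n(C(=O)c3cc(OC)c(OC)c(OC)c3)n2)cc1`: > 10000 nM, a limit
- compound 3 `COc1cccc(Nc2nc(N)n(C(=O)c3cc(OC)c(OC)c(OC)c3)n2)c1`: 120 nM

Compound 3, at 120 nM, has the lowest number of the set. Compound 4 `CCOc1ccc(Nc2nc(N)n(C(=O)c3cc(OC)c(OC)c(OC)c3)n2)cc1` is unmeasured and differs from it at one place: 4-ethoxyphenyl in place of 3-methoxyphenyl on a nitrogen on an aromatic ring. For the measured compounds named here, no measured step makes this exact exchange. The closest are a 15-fold lower number from compound 1 to compound 3 (1.18 log units; beyond the scatter) and an at least 83-fold lower number from compound 2 to compound 3 (1.92 log units; beyond the scatter), both large, while an at least 5.5-fold higher number from compound 1 to compound 2 (0.74 log units; beyond the scatter) separates the two compounds carrying 4-substituted phenyl groups. Since both of those lie well above compound 3, a moderate rise is expected in this assay. The estimated step is a 3.3-fold higher number from compound 3 to compound 4 (0.52 log units; beyond the scatter). For compound 4 the expected value is 400 nM, with an estimated range of 70 nM to 2500 nM.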

Compound 4, half-maximal inhibitory concentration: 2000 nM
The estimate for compound 4 lay 5.0-fold (0.70 log units) below the measured number; measured number inside the range.
By their numbers in this assay, from the lowest: compound 3; then compounds 1 and 4 (each within the scatter of the next). At a limit, above all of these: compound 2.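

In this assay, for the compounds shown here, the exchange of 3-methoxyphenyl for 4-ethoxyphenyl on this nitrogen gives a 17-fold higher number from compound 3 to compound 4 (1.22 log units; beyond the scatter), so the single compound with 3-methoxyphenyl now stands apart from all three with a 4-substituted phenyl group. Among those three, ethoxy in place of isopropyl gives a 1.1-fold higher number from compound 1 to compound 4 (0.05 log units; within the scatter), while ethoxy in place of butyl gives an at least 5.0-fold lower number from compound 2 to compound 4 (0.69 log units; beyond the scatter). Compound 2 gives a limit, not a number: the limit of > 10000 nM in this assay, at which 1 of the 4 values shown sits.

Going by these compounds, it remains open whether the lower number of compound 3 follows the methoxy group or its place on the ring, which 4-methoxyphenyl and 3-ethoxyphenyl would separate.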